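Ethyl to Benzyl Ester, Measured Once and Repeated

The source may report more compounds than this note shows. Statements on the series, on what has been measured and on what is new or still open speak of the compounds shown alone.

Measured compounds:
compound 1, `CCOC(=O)c1c(-c2ccc(OC)c(OC)c2)csc1N`, 100%
compound 2, `COc1ccc(-c2csc(N)c2C(=O)OCc2ccccc2)cc1OC`, 100%
compound 3, `CCOC(=O)c1c(-c2cccc(C)c2)csc1N`, 77%

In an assay on isolated protein for inhibition of protein kinase C zeta type (Homo sapiens), with stated times of 1 h and 2.5 min, tested at 30 uM (on this read-out higher numbers stand for more inhibition at the one concentration tested (going by the name of the read-out) and lower numbers for less inhibition), compound 1 gives 100% and compound 2 gives 100%. The change between them, (phenyl in place of methyl on a saturated chain carbon bound to an oxygen next to a carbonyl group), made no change at the digits printed from compound 1 to compound 2 (within the scatter); both compounds sit at the top of the read-out. Compound 3 gives 77%, the lowest of the three numbers, beyond the scatter from compound 1 and compound 2 alike. The difference between the cores of compound 1 and compound 3 is not broken down here.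

Compound 4, `Cc1cccc(-c2csc(N)c2C(=O)OCc2ccccc2)c1`, is not yet measured. It differs from compound 3 by phenyl in place of methyl on a saturated chain carbon bound to an oxygen next to a carbonyl group, the same change as from compound 1 to compound 2, at a place described in the same words. The earlier step, no change at the digits printed from compound 1 to compound 2 (within the scatter), was made from a starting number already at the top of the read-out and so cannot show a direction. Compound 3 starts lower, leaving room either way. For the measured compounds named here, the step expected from this change is a number 3 percentage points higher from compound 3 to compound 4 (within the scatter), resting on the single earlier step within the scatter. Compound 4 is estimated to give 80%, between 60% and 100%.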

Compound 4, a percentage reported as inhibition, at one concentration (the size of the read-out at that concentration, not a potency): 68%
The estimate for compound 4 lay 12 percentage points above the measured number; low and high end bracket the measured number.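

Carried onto the core of compound 3, the change of methyl to phenyl on a saturated chain carbon bound to an oxygen next to a carbonyl group, which reads ethyl to benzyl when cut one bond further out, gives a number 9 percentage points lower from compound 3 to compound 4 (within the scatter) in this assay. Set beside the earlier pair, the change reads alike on the two cores: the same change on two cores in this assay, no change at the digits printed (within the scatter) from compound 1 to compound 2 and a number 9 percentage points lower (within the scatter) from compound 3 to compound 4, 9 percentage points apart, within the scatter of two such steps. This does not establish a rule for carrying the change to other cores: only two cores are shown, the first pair sits at the top of the read-out, and a single concentration gives no potency.

The compounds shown leave open how a longer chain in place of ethyl, or a carboxylic acid or an amide in place of the ester, would read in this assay. They also leave open how the ethyl to benzyl change would read on a core carrying a nitrile in place of the ring methyl of compound 3.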